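A hydrazone series: compound 2 to compound 3

The source may report more compounds than this note shows. Statements on the series, on what has been measured and on what is new or still open speak of the compounds shown alone.

The shared core carries a hydrazone arm, and within this set the compounds differ in the aryl group at the end of that arm. Compound 1 `CN(C)Cc1cccc(/C=N/Nc2ncnc3sc(C(C)(C)C)cc23)n1` was measured in a functional assay on HCT-116 cells (Homo sapiens) for cytotoxicity, read by MTT assay, with a stated time of 3 days (a higher number here means a weaker inhibitor, a lower number a stronger inhibitor), where compound 1 gives 0.419 ug/mL. Compound 2 `COC(=O)c1ccc(/C=N/Nc2ncnc3sc(C(C)(C)C)cc23)cc1` has no number to stand on: in this assay compound 2 gives "not determined" (no result reported). Compound 3 `CNCc1ccc(/C=N/Nc2ncnc3sc(C(C)(C)C)cc23)cc1` awaits measurement in this assay. The change from compound 2 to compound 3 is (methylamino)methyl in place of methoxycarbonyl on an aromatic carbon. Within the data shown here, with no value for compound 2, no size or direction of step in this assay can be drawn between compound 2 and compound 3, and the only anchor is compound 1 with 0.419 ug/mL. On that anchor alone, compound 3 is expected to give an estimated 0.5 ug/mL in this assay, with a plausible range from 0.15 ug/mL to 2 ug/mL.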

Compound 3, half-maximal inhibitory concentration: 0.056 ug/mL
Beside the measured number, compound 3's estimate is 8.9-fold (0.95 log units) above it; the whole stated range lies above it.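

Among these compounds, compound 2 has no number in this assay, and no step to compound 3 can be read from it. From the compounds shown here alone, what replacing methoxycarbonyl with (methylamino)methyl does to cytotoxicity therefore stays open. Nothing measured here offers an explanation for the value of compound 3.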